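Moving the Fluorine Around the Pendant Aryl Ring

This account rests on a few compounds, and the source may have more. Where it says the series, first, only, none or still open, it means among the compounds named here.

Two compounds share one core and differ only in the group carried on the pendant aromatic ring. Compound 1 `CCC1=C(O)c2c(oc(-c3ccc(CC(C)C)cc3)cc2=O)C(CC)(CC)C1=O` bears an isobutyl there, compound 2 `CCC1=C(O)c2c(oc(-c3ccc(F)cc3)cc2=O)C(CC)(CC)C1=O` a fluoro. In a functional assay on KB cells (Homo sapiens) for antiproliferative activity, read by sulforhodamine B assay, with a stated time of 3 days (on this read-out lower numbers stand for an effect already at smaller amounts and higher numbers for an effect only at larger amounts of compound), compound 1 gives 29.3 uM, and in the same assay compound 2 gives 33 uM. The step of a 1.1-fold higher number from compound 1 to compound 2 (0.05 log units; within the scatter) is small, so the two numbers cannot be ordered with confidence. Among the measured compounds shown here, compound 2 holds the higher of the two numbers, yet its only neighbour, compound 1, sits within the scatter of it.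

Compound 3 `CCC1=C(O)c2c(oc(-c3ccccc3F)cc2=O)C(CC)(CC)C1=O` has not been measured. It differs from compound 2 as follows: 2-fluorophenyl in place of 4-fluorophenyl on an aromatic carbon. For the measured compounds named here, no measured step concerns a shift of the fluorine around this ring; the single known step, a 1.1-fold higher number from compound 1 to compound 2 (0.05 log units; within the scatter), swaps one group for another at the same carbon and stays within the scatter. With nothing to point either way, compound 3 is expected to stay close to compound 2, an estimated no change at the digits printed from compound 2 to compound 3 (within the scatter). Compound 3 is therefore estimated at 33 uM, with a range from 12 uM to 90 uM.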

Compound 3, concentration for half-maximal effect: > 56.2 uM
Compound 3 was reported as a limit; the forecaster's own chance of this, stated with the estimate: 5%; at least 1.7-fold (0.23 log units) between middle value and limit.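

Exchanging 4-fluorophenyl for 2-fluorophenyl, with the same atoms joined differently, gives in this assay an at least 1.7-fold higher number from compound 2 to compound 3 (0.23 log units; that floor lies within the scatter). This is the first step shown that moves a group around the pendant ring rather than replacing it at the same carbon, but because its floor lies within the scatter, it does not establish that the place of the fluorine matters on this read-out, though it remains possible that the shift has a larger effect than the floor shows. The reading for compound 3 is a limit and not a measured number: the limit of > 56.2 uM in this assay, at which 1 of the 3 values shown sits.

The compounds shown leave open whether an amine, a carboxylic acid or a longer chain in place of the fluoro on the pendant ring would move the number beyond the scatter, which neither the isobutyl of compound 1 nor the fluoro of compound 2 tells. They also leave open whether a chloro or the isobutyl of compound 1, moved around the ring in the same way as the fluorine, would behave as the fluorine does.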